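Three Hydrazones at the Limit, a Fourth Expected There

A few compounds are considered here, and "the series" means these few. Any claim that something is new, unique, unknown or untested is made for them only; others in the source may bear on it.

Compound 3 `Cc1nc2cc(C(=O)N/N=C\c3c[nH]c4ccccc34)c([N+](=O)[O-])cc2[nH]1` is one of three measured members of a small hydrazone set built on a shared core. In a functional assay on MCF7 cells (Homo sapiens) for cytotoxicity, read by resazurin assay, with a stated time of 72 h (a lower number here means a stronger inhibitor, a higher number a weaker inhibitor), compound 3 gives > 100000 nM, which is a limit of the assay and not a number. Compound 1 `Cc1nc2cc(C(=O)N/N=C\c3ccc(C)o3)c([N+](=O)[O-])cc2[nH]1` gives > 100000 nM in this assay, likewise a limit. Compound 2 `Cc1nc2cc(C(=O)N/N=C\c3ccccn3)c([N+](=O)[O-])cc2[nH]1` gives > 100000 nM, again a limit. Because every value shown sits at the limit of > 100000 nM in this assay, at which 3 of the 3 values shown sit, the steps a step that the two limits leave unreadable from compound 1 to compound 2, a step that the two limits leave unreadable from compound 1 to compound 3 and a step that the two limits leave unreadable from compound 2 to compound 3 cannot be read in size or direction.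

Compound 4 `Cc1ccc(/C=N\NC(=O)c2cc3nc(C)[nH]c3cc2[N+](=O)[O-])cc1` differs from compound 3 by 4-methylphenyl in place of 1H-indol-3-yl on a carbon with a double bond to nitrogen. The three measured steps all exchanged the group on that same carbon, and none moved a value off the limit, so they give no size to carry forward. No step beyond the scatter is therefore expected, and the step from compound 3 to compound 4 is estimated as a step that the limit leaves unreadable from compound 3 to compound 4. Compound 4 is expected to give about 150000 nM in this assay, most likely reported again as a limit, within a range from 40000 nM to 600000 nM.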

Compound 4, half-maximal inhibitory concentration: 3000 nM
Compound 4: the middle estimate sits 50-fold (1.70 log units) above what was measured, outside the stated range (below it).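

For the compounds shown here, the carbon with a double bond to nitrogen, which had seemed silent in this assay, proves responsive to the group it carries: with 4-methylphenyl there, compound 4 gives 3000 nM, the only value shown that is not a limit. Exchanging each earlier group for 4-methylphenyl gives an at least 33-fold lower number from compound 3 to compound 4 (1.52 log units; beyond the scatter), an at least 33-fold lower number from compound 2 to compound 4 (1.52 log units; beyond the scatter) and an at least 33-fold lower number from compound 1 to compound 4 (1.52 log units; beyond the scatter). These sizes are bounds and the steps among the three earlier compounds remain unreadable: the limit of > 100000 nM in this assay, at which 3 of the 4 values shown sit.

The compounds shown leave open whether the methyl group of 4-methylphenyl is needed, as plain phenyl would show, or whether the six-membered carbon ring alone accounts for the value. They also leave open how the value would respond to an ethyl group, a methoxy group, an amine or a carboxylic acid on that ring.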